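Diastereomer of compound 2 in a dopamine transporter assay

The compounds below may be only part of what the source reports. "The series", "measured", "known", "first", "only" and "open" are said of these compounds alone.

Measured compounds:
compound 1, `CCCCOc1ccc([C@@H]2CC[C@@H](NC)c3ccccc32)cc1`, 6800 nM
compound 2, `CN[C@@H]1CC[C@@H](c2ccc(Oc3ccccc3)cc2)c2ccccc21`, 8400 nM
compound 3, `CN(C)[C@@H]1CC[C@@H](c2ccccc2)c2ccccc21`, 840 nM

In a functional assay on striatum for inhibition of sodium-dependent dopamine transporter (Rattus norvegicus) (on this read-out lower numbers stand for stronger inhibition and higher numbers for weaker inhibition), compound 2 gives 8400 nM, the highest of the three numbers. Compound 1 sits nearest, with a 1.2-fold higher number from compound 1 to compound 2 (0.09 log units; within the scatter) for phenyl in place of butyl on an oxygen on an aromatic ring. Compound 3 differs from compound 2 in more than one place; in this assay compound 3 gives 840 nM, a much lower number than compound 2.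

Compound 4, `CN[C@H]1CC[C@@H](c2ccc(Oc3ccccc3)cc2)c2ccccc21`, keeps all atoms and bonds of compound 2: the two compounds have the same atoms and bonds and differ only in configuration as drawn: 1 of 2 stereo elements differ; a stereocentre at a saturated ring carbon is drawn R in compound 2 and S in compound 4. For the measured compounds named here, none of the measured steps changes a stereocentre, so no step bears directly on this change; the only step available, from compound 1 to compound 2, concerns an aryl ether and is within the scatter. A change of configuration at a ring carbon can shift this read-out in either direction, and the data give no basis to pick one. The step from compound 2 to compound 4 is therefore expected to be a 1.7-fold lower number from compound 2 to compound 4 (0.23 log units; within the scatter), with wide uncertainty. Compound 4 is estimated at 5000 nM in this assay, within a range from 800 nM to 30000 nM.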

Compound 4, half-maximal inhibitory concentration: 6800 nM
Compound 4: middle estimate off by 1.4-fold (0.13 log units), on the low side; the range from low to high includes it.
By their numbers in this assay, from the lowest: compound 3; then compounds 1, 4 and 2 (each within the scatter of the next).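

In this assay, turning a stereocentre at a saturated ring carbon from R to S gives a 1.2-fold lower number from compound 2 to compound 4 (0.09 log units; within the scatter). For the compounds shown here, this is the first measured step at a stereocentre here, since the earlier step concerned only the group on the oxygen. With phenyl on that oxygen, the read-out therefore does not separate these two configurations at this carbon, and the comparison speaks to configuration alone: the fact that compounds 2 and 4 differ only in the configuration as drawn.

On these data alone, whether inverting this carbon changes as little with butyl on the oxygen, as in compound 1, or with a primary amine or an ethylamine in place of the methylamine, stays open. So does the role of the second stereocentre, which compound 2 and compound 4 share as drawn.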